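The source may hold more compounds than are shown below. What is called first, only, known or untested is meant among the compounds shown, and "the series" means these compounds.

Compound 1 `CC(=O)SCC(=O)c1ccc(NS(=O)(=O)c2ccc(OCCCN3CCCCC3)cc2)nc1` — 800 nM
Compound 2 `CC(=O)SCC(=O)c1ccc(NS(=O)(=O)c2ccc(OCc3ccccn3)cc2)nc1` — "not determined" (no result reported)
Compound 3 `COc1cccc(S(=O)(=O)Nc2ccc(C(=O)CSC(C)=O)cn2)c1` — "not determined" (no result reported)

Three compounds were examined in a functional assay on U226 cells (Homo sapiens) for cytotoxicity; on this read-out higher numbers stand for an effect only at larger amounts of compound and lower numbers for an effect already at smaller amounts. Within the data shown here, compound 1 is the only one for which a number is given; in this assay compound 1 gives 800 nM. Among the measured compounds shown here, for compound 2 the entry reads "not determined" (no result reported), and for compound 3 the entry reads "not determined" (no result reported), so compound 1 stands alone among the measured entries and no step between measured compounds can be drawn.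

The step considered here leads from compound 1 to compound 4 `CC(=O)SCC(=O)c1ccc(NS(=O)(=O)c2ccc(OC3CCCN(C)C3)cc2)nc1`. The two differ in one place: 1-methylpiperidin-3-yl in place of 3-(piperidin-1-yl)propyl on an oxygen on an aromatic ring. The group that leaves and the group that enters each carry one six-membered non-aromatic ring with one hetero atom and one hydrogen-bond acceptor, and neither has a net charge, so the change is modest in count.

For the measured compounds named here, with no measured step available, only a cautious expectation is possible. Compound 4 is expected to stay close to compound 1, with a step of a 1.3-fold higher number from compound 1 to compound 4 (0.10 log units; within the scatter) that is expected to be at or just beyond the usual scatter, if anything toward weaker. Compound 4 is therefore estimated at 1000 nM in this assay, within a range from 400 nM to 2500 nM.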

Compound 4, half-maximal effective concentration: 1200 nM
Estimate against measurement, compound 4: 1.2-fold (0.08 log units) below; measured number inside the range.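

In this assay, 1-methylpiperidin-3-yl in place of 3-(piperidin-1-yl)propyl gives a 1.5-fold higher number from compound 1 to compound 4 (0.18 log units; within the scatter), so the two compounds read alike. Until now this position had a single number, and it now has a second: on the oxygen on an aromatic ring, the 3-(piperidin-1-yl)propoxy group can be exchanged for (1-methylpiperidin-3-yl)oxy with the cytotoxicity read-out kept within the scatter.

The compounds shown leave open whether the ring nitrogen matters at all, since a cyclohexyl group or a tetrahydropyranyl group on the same oxygen would test this directly. They also leave open how far the position accepts other kinds of group, such as a morpholine on a longer chain or a carboxylic acid. No measurement shown here offers an explanation for the similarity of the two values.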